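Removing the arginine-like side chain from a purine glycinamide ester

The source may report more compounds than this note shows. Statements on the series, on what has been measured and on what is new or still open speak of the compounds shown alone.

Measured so far:
compound 1, `C[C@H](NC(=O)CN(c1nc(Cl)nc2c1ncn2C1CCCCO1)C1CC1)C(=O)OCc1ccccc1`, 11.4%
compound 2, `N=C(N)NCCC[C@H](NC(=O)CN(c1nc(Cl)nc2c1ncn2C1CCCCO1)C1CC1)C(=O)OCc1ccccc1`, 32.9%

Both compounds were tested in a functional assay on the whole organism with Mus musculus as the target, with a stated time of 90 min, at a dose of 0.3 umol/kg by the oral route; a lower number here means a weaker effect, a higher number a stronger effect of the compound at the dose given. Compound 2 stands highest of the two numbers; its nearest neighbour is compound 1, whose number lies lower by a margin beyond the scatter. For the measured compounds named here, the only measured step, a number 21.5 percentage points higher from compound 1 to compound 2 (beyond the scatter), came from a group of 6 heavy atoms (3 carbon, 3 nitrogen; no ring) entering in place of a hydrogen atom on a saturated chain carbon.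

Compound 3, `O=C(CN(c1nc(Cl)nc2c1ncn2C1CCCCO1)C1CC1)NCC(=O)OCc1ccccc1`, has not been measured yet. It differs from compound 2 by a hydrogen atom in place of a group of 7 heavy atoms (4 carbon, 3 nitrogen; no ring), on a saturated chain carbon bound to an amide-type nitrogen and a carbonyl carbon. Going by the values given here, this change strips away the very kind of group whose arrival raised the number in the step from compound 1 to compound 2, so the one relevant step points to a decline of comparable size, beyond the scatter, for compound 3 in this assay.

Compound 3 is therefore expected to show a number 20.9 percentage points lower from compound 2 to compound 3 (beyond the scatter), landing at an estimated 12%, within a range from 3% to 25%.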

Compound 3, a percentage reported as activity, at one dose (the size of the read-out at that dose, not a potency): 11.2%
Estimate against measurement, compound 3: 0.8 percentage points above, and the stated range covers the measured number.
By their numbers in this assay, from the lowest: compounds 3 and 1 (each within the scatter of the next); then compound 2.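

In this assay the saturated chain carbon bound to an amide-type nitrogen and a carbonyl carbon can now be compared with three different substituents: hydrogen, methyl and the group of 7 heavy atoms. Putting a hydrogen atom in place of that group gives a clear drop (a number 21.7 percentage points lower from compound 2 to compound 3 (beyond the scatter)), whereas hydrogen in place of methyl leaves the two compounds indistinguishable (a number 0.2 percentage points lower from compound 1 to compound 3 (within the scatter)), so among these three compounds only the group of 7 heavy atoms sets one apart, and the methyl group makes no difference that this read-out can detect. Nothing measured here explains why the larger group has this effect.

The compounds shown leave open which part of that group matters: a plain butyl chain, a chain of the same length ending in an amine, or a carboxylic acid on the same carbon could show whether the chain alone is enough or its nitrogen-bearing end is needed. As far as these compounds go, all three numbers also come from a single oral dose, so how the compounds would compare at other doses remains unknown.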